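The source may hold more compounds than are shown below. What is called first, only, known or untested is meant among the compounds shown, and "the series" means these compounds.

Measured compounds:
- compound 1, `COc1ccc(C2SCC(=O)N2CCN2CCCCC2)cc1`, in an ADME assay on Vero cells (Chlorocebus sabaeus) for cytotoxicity, read by neutral red uptake, tested at 787 ug/mL (on this read-out lower numbers stand for a stronger effect and higher numbers for a weaker effect at the one concentration tested), compound 1 gives 33%
- compound 2, `O=C1CSC(c2cccc(Cl)c2)N1CCN1CCCCC1`, compound 2 gives 31%
- compound 3, `O=C1CSC(c2ccc(O)cc2)N1CCN1CCCCC1`, compound 3 gives 57%

Compound 3 stands highest of the three, and both of its steps lie beyond the scatter: a number 24 percentage points higher from compound 1 to compound 3 (beyond the scatter) and a number 26 percentage points higher from compound 2 to compound 3 (beyond the scatter). Compound 4, `O=C1CSC(c2ccc([N+](=O)[O-])cc2)N1CCN1CCCCC1`, differs from compound 3 by nitro in place of hydroxy on an aromatic carbon. No measured step swaps hydroxy for nitro, so nothing bears on it directly; both shown steps only say that arriving at the hydroxy compound raised the number by a modest amount. Taking the hydroxy away is therefore expected to send the number back down by a modest step, a number 19 percentage points lower from compound 3 to compound 4 (beyond the scatter). Compound 4 is estimated at 38%, within 20% to 60%.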

Compound 4, a percentage reported as activity, at one concentration (the size of the read-out at that concentration, not a potency): 21%
Estimate against measurement, compound 4: 17 percentage points above; the range from low to high includes it.
By their numbers in this assay, from the lowest: compounds 4, 2 and 1 (each within the scatter of the next, the first and the last beyond it); then compound 3.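

In this assay, the aromatic carbon para to a large group can move the number in either direction: nitro in place of hydroxy gives a number 36 percentage points lower from compound 3 to compound 4 (beyond the scatter), and nitro in place of methoxy gives a number 12 percentage points lower from compound 1 to compound 4 (beyond the scatter). The earlier compounds shown here showed only a rise on arriving at hydroxy, whereas nitro shows that this position can also take the number past the methoxy compound in the other direction. Nothing at hand accounts for this difference. From the compounds shown here alone, whether an amine or a carboxylic acid at this position would side with hydroxy or with nitro remains open.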